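Methyl in place of hydrogen: cytotoxicity notes on the series

A few compounds are considered here, and "the series" means these few. Any claim that something is new, unique, unknown or untested is made for them only; others in the source may bear on it.

In a toxicity assay on MDCK cells (Canis lupus familiaris) for cytotoxicity, read by crystal violet staining, with a stated time of 48 h (on this read-out lower numbers stand for higher toxicity in this test and higher numbers for lower toxicity in this test), compound 1 `Cc1ccc2[nH]c(=O)c(CN(Cc3ccc(C(C)(C)C)cc3)[C@@H](C)c3ccc(F)cc3)cc2c1` reaches only a limit, > 5000 nM, not a number. Compound 2 `CCc1ccc2[nH]c(=O)c(CN(Cc3ccc(C(C)(C)C)cc3)[C@@H](C)c3ccc(F)cc3)cc2c1` likewise returns a limit in this assay, namely > 5000 nM. The change between these two, (methyl in place of hydrogen on a saturated chain carbon bound to an aromatic carbon), yields a step that the two limits leave unreadable from compound 1 to compound 2, unreadable because of the limit of > 5000 nM in this assay, at which 2 of the 3 values shown sit.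

Among the compounds with values here, compound 3 `COc1ccc(CN(Cc2ccc(C(C)(C)C)cc2)Cc2cc3ccccc3[nH]c2=O)cc1` is the only one with a number: in this assay compound 3 gives 1800 nM. How its core differs from the core of compound 1 is not broken down here.

Compound 4 `COc1ccc([C@H](C)N(Cc2ccc(C(C)(C)C)cc2)Cc2cc3ccccc3[nH]c2=O)cc1` is not yet measured and carries methyl in place of hydrogen on a saturated chain carbon bound to an amine nitrogen and an aromatic carbon. This is the same kind of change as from compound 1 to compound 2, but not the same: there the place is a saturated chain carbon bound to an aromatic carbon, here a saturated chain carbon bound to an amine nitrogen and an aromatic carbon.

The earlier step is not readable; the expectation rests on compound 3 at 1800 nM alone. From there compound 4 is expected to shift by a 1.4-fold higher number from compound 3 to compound 4 (0.14 log units; within the scatter). In this assay compound 4 is estimated at 2500 nM, expected between 900 nM and 6000 nM.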

Compound 4, half-maximal cytotoxic concentration: 1800 nM
Compound 4: middle estimate off by 1.4-fold (0.14 log units), on the high side, within the range that was stated.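

In this assay, methyl in place of hydrogen on a saturated chain carbon bound to an amine nitrogen and an aromatic carbon gives no change at the digits printed from compound 3 to compound 4 (within the scatter). This shows that the two compounds of this one pair cannot be told apart in this test, and a single pair does not establish a rule for the series. It does not show that the change behaves alike on another core, as the step on the core of compound 1, at a different place, cannot be read because both of its values are limits: the limit of > 5000 nM in this assay, at which 2 of the 4 values shown sit.

Open, from the compounds shown here alone, is whether a longer chain, such as propyl, or an amine at this saturated chain carbon would separate from compound 3 in this assay. Also open, going by these compounds, is how the mirror-image arrangement at that carbon would read.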